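Compound 2 to compound 4: losing the amine side chain

This account rests on a few compounds, and the source may have more. Where it says the series, first, only, none or still open, it means among the compounds named here.

Measured so far:
- compound 1 `CC(C)=CCC[C@H](C)c1ccc(C)c(CNCC2CCNCC2)c1O`: > 20000 nM
- compound 2 `CC(C)=CCC[C@H](C)c1ccc(C)c(CNCCCCCO)c1O`: > 20000 nM
- compound 3 `CCOC(CCNCc1c(C)ccc([C@@H](C)CCC=C(C)C)c1O)OCC`: > 20000 nM

Each of these entries is a limit and not a number. Going by the values given here, the series so far comes from an ADME assay on MDA-MB-231 cells (Homo sapiens) for inhibition, read by MTT assay, with a stated time of 24 h (on this read-out higher numbers stand for weaker inhibition and lower numbers for stronger inhibition), and it sits at a single ceiling: the limit of > 20000 nM in this assay, at which 3 of the 3 values shown sit.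

In this assay compound 2 gives > 20000 nM, which is a limit, so its standing within the series cannot be ranked.

Compound 4 `CC(C)=CCC[C@H](C)c1ccc(C)c(CO)c1O` is the next to be read. The change is hydroxy in place of (5-hydroxypentyl)amino on a saturated chain carbon bound to an aromatic carbon.

Three measured steps come closest: a step that the two limits leave unreadable from compound 1 to compound 2, a step that the two limits leave unreadable from compound 1 to compound 3 and a step that the two limits leave unreadable from compound 2 to compound 3. None has a readable size, and all three keep the amine nitrogen, so none tests this change directly. Among the compounds with values here, no sized step or direction can therefore be carried over to this assay, and the most likely outcome is that compound 4 also reports only a limit. The expectation rests on (the limit of > 20000 nM in this assay, at which 3 of the 3 values shown sit).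

Expected, with low confidence, is a step that the limit leaves unreadable from compound 2 to compound 4. For compound 4 the estimated value is 25000 nM, with an expected range from 10000 nM to 60000 nM.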

Compound 4, half-maximal inhibitory concentration: > 20000 nM
Compound 4 gave a limit, no number; the forecaster's own chance of this, stated with the estimate: 75%; the middle value does not contradict the limit.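

In this assay compound 4 gives > 20000 nM, which is a limit and not a number. The steps to compound 4 from compound 1 and from compound 2 cannot be read, as the series stays at a single ceiling: the limit of > 20000 nM in this assay, at which 4 of the 4 values shown sit.

The compounds shown leave open whether any change on the shared core gives a measurable value in this assay.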